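Swapping the Ring on Compound 2: An Expected Limit

A few compounds are considered here, and "the series" means these few. Any claim that something is new, unique, unknown or untested is made for them only; others in the source may bear on it.

Of the compounds shown here, three have so far been tested in a functional assay on SW-620 cells (Homo sapiens) for inhibition, read by MTT assay, with a stated time of 72 h; a lower number here means a stronger inhibitor, a higher number a weaker inhibitor. Compound 1 `Nc1ncn(C/C=C2\OC(=O)C(OCc3ccccc3)=C2OCc2ccccc2)c(=O)n1` gives 5620 nM. Compound 2 `NC1(CCn2cc(F)c(=O)[nH]c2=O)OC(=O)C(OCc2ccccc2)=C1OCc1ccccc1` reaches only the limit of the assay, > 100000 nM, so no number is known for it. Compound 3 `O=C1O[C@H]([C@@H](O)Cn2ccc(NC(=O)c3ccccc3)nc2=O)C(OCc2ccccc2)=C1OCc1ccccc1` likewise stops at the limit, > 100000 nM. Compound 2 thus stands where two of the three results sit, namely at the limit of > 100000 nM in this assay, at which 2 of the 3 values shown sit, with no measurable potency to its name. Compound 4 `NC1(CCn2c(=O)[nH]c(=O)[nH]c2=O)OC(=O)C(OCc2ccccc2)=C1OCc1ccccc1` has not yet been measured. It differs from compound 2 in one place: a group of 9 heavy atoms (3 carbon, 3 nitrogen, 3 oxygen; one six-membered aromatic ring with 3 hetero atoms) in place of a group of 9 heavy atoms (4 carbon, 2 nitrogen, 2 oxygen, 1 fluorine; one six-membered aromatic ring with 2 hetero atoms), on a saturated chain carbon, two bonds along the chain from a saturated ring carbon. Among the measured compounds shown here, no measured pair shows what such an exchange does in this assay, so the expectation rests on compound 2 alone. Starting from a limit, the step is expected to be a number no higher from compound 2 to compound 4 (the limit leaves the size open), which means nothing beyond the usual scatter, and the most probable outcome is another limit rather than a number. Compound 4 is therefore estimated at 100000 nM, with a plausible range from 30000 nM to 300000 nM.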

Compound 4, half-maximal inhibitory concentration: > 100000 nM
Compound 4 gave a limit, no number; the forecaster's own chance of this, stated with the estimate: 75%; the middle value sits exactly at the limit.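

Compound 2 and compound 4 both stop at a limit of this assay, not at a number, and the step between them cannot be read. The compounds shown leave open how the two rings truly compare, and how potent either compound actually is.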